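Amide cap variation on the shared core

The source may hold more compounds than are shown below. What is called first, only, known or untested is meant among the compounds shown, and "the series" means these compounds.

Measured in an assay on THP-1 cells for displacement of a labelled ligand from C-C chemokine receptor type 1 (Homo sapiens); on this read-out lower numbers stand for stronger inhibition and higher numbers for weaker inhibition:
compound 1 `Cc1ccc(CCC(=O)N[C@@H](C(=O)N2CCC(c3ccc(Cl)cc3)CC2)C(C)C)cc1` gives 105 nM
compound 2 `CC[C@@H](NC(=O)c1ccccc1)C(=O)N1CCC(c2ccc(Cl)cc2)CC1` gives 121 nM
compound 3 `CC[C@@H](NC(=O)CC(C)C)C(=O)N1CCC(c2ccc(Cl)cc2)CC1` gives 152 nM

Among the measured compounds shown here, compound 3 sits within the scatter of both compound 2 and compound 1; the single measured step, a 1.3-fold higher number from compound 2 to compound 3 (0.10 log units; within the scatter), does not leave the scatter, and the values of compound 3 and compound 1 likewise lie close together. Compound 4 `CC[C@@H](NC(=O)CCc1ccccc1)C(=O)N1CCC(c2ccc(Cl)cc2)CC1` differs from compound 3 by benzyl in place of isopropyl on a saturated chain carbon bound to a carbonyl carbon. The step from compound 2 to compound 3 is the only one that touches the cap on the carbonyl carbon, and it was small; compound 1, which carries an aromatic ring on a chain of this kind, also gives a number close to compound 3. No movement beyond the scatter is therefore expected, and the estimated step is a 1.4-fold lower number from compound 3 to compound 4 (0.14 log units; within the scatter). Compound 4 is expected near 110 nM, between 50 nM and 250 nM.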

Compound 4, half-maximal inhibitory concentration: 85 nM
Compound 4: middle estimate off by 1.3-fold (0.11 log units), on the high side, within the range that was stated.
By their numbers in this assay, from the lowest: compounds 4, 1, 2 and 3 (each within the scatter of the next).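

In this assay, going from isobutyl to phenethyl on this cap stays within the scatter (a 1.8-fold lower number from compound 3 to compound 4 (0.25 log units; within the scatter)), even with a six-membered aromatic ring entering on the chain. Moving from phenyl on the carbonyl carbon to phenethyl also stays within it (a 1.4-fold lower number from compound 2 to compound 4 (0.15 log units; within the scatter)), so compounds 2, 3 and 4 show no measurable preference among these three caps. No evidence bears on why these caps read alike.

As far as these compounds go, whether a cap carrying an amine or a carboxylic acid would leave the scatter remains open. The same holds for a chain longer than phenethyl.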